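The source may report more compounds than this note shows. Statements on the series, on what has been measured and on what is new or still open speak of the compounds shown alone.

Compound 1 `CCc1nc(-c2ccc(Cl)cc2Cl)c(CC)nc1SC(C)CC`: 0.0683 h
Compound 2 `CCOc1ccc(-c2nc(OC)c(NC(CC)CC)nc2C)c(Cl)c1`: 0.783 h
Compound 3 `CCC(CC)Nc1nc(C)c(-c2ccc(Cl)cc2Cl)nc1C`: 0.0533 h

These three numbers come from an in vitro ADME assay on microsomes (Rattus norvegicus) for metabolic stability; on this read-out higher numbers stand for a longer-lived compound and lower numbers for a shorter-lived compound. Compound 1 stands second highest of the three. Its nearest neighbour is compound 3, whose number is a little lower but within the usual scatter, so the two cannot be told apart. Compound 2 sits far above compound 1, well beyond the scatter.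

Compound 4 `CCc1nc(-c2ccc(Cl)cc2Cl)c(CC)nc1NC(C)CN(C)C` has not yet been measured. It differs from compound 1 in one place: (1-((dimethylamino)methyl)ethyl)amino in place of (sec-butyl)sulfanyl on an aromatic carbon. Among the measured compounds shown here, no pair of measured compounds shows this exact change, so its effect is uncertain. Compound 4 is expected to give a small upward step in this assay, a 1.8-fold higher number from compound 1 to compound 4 (0.24 log units; within the scatter), which may not exceed the scatter. The estimate for compound 4 is 0.12 h, ranging from 0.04 h to 0.4 h.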

Compound 4, half-life: < 0.0167 h
Compound 4 was reported as a limit; the forecaster's own chance of this, stated with the estimate: 5%; middle value at least 7.1-fold (0.85 log units) away from the limit.
By their numbers in this assay, from the lowest: compounds 3 and 1 (each within the scatter of the next); then compound 2. At a limit, below all of these: compound 4.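

Among the compounds shown here, the earlier compounds offered no single-place change, so this is the first reading at this position, on an aromatic carbon next to the ring nitrogen: in this assay, (1-((dimethylamino)methyl)ethyl)amino in place of (sec-butyl)sulfanyl gives an at least 4.0-fold lower number from compound 1 to compound 4 (0.61 log units; beyond the scatter). For compound 4, < 0.0167 h is a limit of the assay and not a number. The full size of the step cannot be read, as it ends at that limit: the limit of < 0.0167 h in this assay, at which 1 of the 4 values shown sits.

The compounds shown do not separate the effect of the amino link from that of the dimethylamino end. A plain sec-butylamino group at this position would tell the two apart.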